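Dropping a hydroxy group from a potent cell growth inhibitor

This account rests on a few compounds, and the source may have more. Where it says the series, first, only, none or still open, it means among the compounds named here.

Measured in a functional assay on HCT-116 cells (Homo sapiens) for inhibition; a higher number here means a weaker inhibitor, a lower number a stronger inhibitor:
Compound 1 `COc1ccc(C2=C(c3cc(OC)c(OC)c(OC)c3)C(=O)CC2)cc1`: 0.021 ug/mL
Compound 2 `COc1ccc(C2=C(c3cc(OC)c(OC)c(OC)c3)C(O)CC2)cc1`: 0.045 ug/mL

Of these two, compound 2 carries the higher number, so it is the weaker inhibitor, and its gap to compound 1 lies just beyond the usual scatter. The next molecule, compound 3 `COc1ccc(C2=C(c3cc(OC)c(OC)c(OC)c3)CCC2)cc1`, differs from compound 2 in a single place: hydrogen in place of hydroxy on a saturated ring carbon. Among the compounds with values here, no measured pair shows this exact swap, so the guide is thin. Within the data shown here, the only comparison at hand is compound 1 at 0.021 ug/mL against compound 2 at 0.045 ug/mL, a modest gap. A slightly higher number in this assay is therefore expected, with no shift beyond the scatter. The expectation is a 1.2-fold higher number from compound 2 to compound 3 (0.09 log units; within the scatter). For compound 3 the estimated value is 0.055 ug/mL, with an expected range from 0.015 ug/mL to 0.2 ug/mL.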

Compound 3, half-maximal inhibitory concentration: > 1 ug/mL
Compound 3 gave a limit, no number; the forecaster's own chance of this, stated with the estimate: 2%; at least 18-fold (1.25 log units) between middle value and limit.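

In this assay, putting hydrogen in place of hydroxy on the saturated ring carbon gives an at least 22-fold higher number from compound 2 to compound 3 (1.34 log units; beyond the scatter) and so shows that this one position matters far more than the modest gap between the two oxygen-bearing compounds suggested. Compound 3 gives > 1 ug/mL as a limit of the assay and not a number. Compound 1, with a carbonyl at this ring carbon, gives 0.021 ug/mL and compound 2, with a hydroxy there, gives 0.045 ug/mL in this assay, so among these three compounds strong inhibition goes with an oxygen at this carbon and is lost with hydrogen alone.

From the compounds shown here alone, whether an amine or a fluorine atom on this ring carbon would keep the strong inhibition stays open. Going by these compounds, what the oxygen does for inhibition in these cells also remains unknown.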